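The source may hold more compounds than are shown below. What is called first, only, known or untested is meant among the compounds shown, and "the series" means these compounds.

Measured in a functional assay on DU-145 cells (Homo sapiens) for cytotoxicity, read by trypan blue exclusion, with a stated time of 96 h; on this read-out higher numbers stand for weaker inhibition and lower numbers for stronger inhibition:
- compound 1 `COc1cc(OC)c(/C=C/S(=O)(=O)Nc2ccc(OC)c(N)c2)c(OC)c1`: 5 nM
- compound 2 `COC(=O)C(Nc1cc(NS(=O)(=O)/C=C/c2c(OC)cc(OC)cc2OC)ccc1OC)c1ccc(Cl)cc1`: 5000 nM
- compound 3 `COc1cc(OC)c(/C=C/S(=O)(=O)Nc2ccc(OC)c(NCC(=O)O)c2)c(OC)c1`: 400 nM

Compound 3 holds the middle of these three numbers. Substitution on the aromatic nitrogen gave large rises in both measured cases: an 80-fold higher number from compound 1 to compound 3 (1.90 log units; beyond the scatter), and a 1000-fold higher number from compound 1 to compound 2 (3.00 log units; beyond the scatter). Compound 4 `COc1cc(OC)c(/C=C/S(=O)(=O)Nc2ccc(OC)c(NC(C(=O)O)c3ccc(F)cc3)c2)c(OC)c1` brings one further change, 4-fluorophenyl in place of hydrogen on a saturated chain carbon bound to a carbonyl carbon and a nitrogen on an aromatic ring. Among the compounds with values here, no measured step isolates this change. The closest guide is compound 2, which also has a phenyl ring on that carbon, but a 13-fold lower number from compound 2 to compound 3 (1.10 log units; beyond the scatter) swaps the ring and the ester together. A moderate rise is therefore expected, estimated as a 2.3-fold higher number from compound 3 to compound 4 (0.35 log units; beyond the scatter). For compound 4 the expected value is 900 nM, with an estimated range of 150 nM to 5000 nM.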

Compound 4, half-maximal inhibitory concentration: 75 nM
Beside the measured number, compound 4's estimate is 12-fold (1.08 log units) above it; the measured number lies below the stated range.
By their numbers in this assay, from the lowest: compound 1; then compound 4; then compound 3; then compound 2.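

In this assay, 4-fluorophenyl on the saturated chain carbon gives a 5.3-fold lower number from compound 3 to compound 4 (0.73 log units; beyond the scatter), so an aromatic ring at this carbon goes with stronger inhibition when the carboxylic acid is present. The whole carboxy(4-fluorophenyl)methyl group still gives a 15-fold higher number from compound 1 to compound 4 (1.18 log units; beyond the scatter), while replacing (4-chlorophenyl)(methoxycarbonyl)methyl with it gives a 67-fold lower number from compound 2 to compound 4 (1.82 log units; beyond the scatter). No measurement shown explains these shifts.

On these data alone, that last step changes the halogen and the ester together, so their separate shares remain unknown. As far as these compounds go, whether an unsubstituted phenyl or a methyl group on this carbon would serve equally also remains open.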